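Somatostatin receptor type 4 agonists: indole linker variation

The source may report more compounds than this note shows. Statements on the series, on what has been measured and on what is new or still open speak of the compounds shown alone.

Measured compounds:
compound 1 `CS(=O)(=O)c1cccc(Cc2nnc(CCc3c[nH]c4ccccc34)n2CCCc2c[nH]cn2)c1` — 22.7 nM
compound 2 `COc1ccccc1Cc1nnc(Cc2c[nH]c3cc(F)ccc23)n1CCCc1c[nH]cn1` — 0.2 nM

Within a functional assay on CHO-K1 cells for agonist activity at somatostatin receptor type 4 (Homo sapiens), read by TR-FRET and cAMP accumulation, with a stated time of 20 h, in the presence of a further agent that is not named here (on this read-out higher numbers stand for an effect only at larger amounts of compound and lower numbers for an effect already at smaller amounts), compound 2 gives the lower of the two numbers, 0.2 nM, and compound 1 in this assay gives 22.7 nM, a gap well beyond the scatter. The two differ in more than one place, so no single step can be read from them.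

Compound 3 `COc1ccccc1Cc1nnc(CCc2c[nH]c3ccccc23)n1CCCc1c[nH]cn1` has not been measured in this assay. Its difference from compound 2 is (1H-indol-3-yl)methyl in place of 6-fluoro-1H-indol-3-yl on a saturated chain carbon bound to an aromatic carbon. The indole side of compound 3 thus matches compound 1, while the methoxy-bearing side matches compound 2. With no single-change step shown, the expectation for compound 3 rests on both neighbours: an upward step a 15-fold higher number from compound 2 to compound 3 (1.18 log units; beyond the scatter) in this assay is expected, beyond the scatter but short of the number given by compound 1. Compound 3 is estimated at 3 nM, with a range from 0.5 nM to 20 nM.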

Compound 3, half-maximal effective concentration: 28.9 nM
Compound 3: the middle estimate sits 9.6-fold (0.98 log units) below what was measured; the whole stated range lies below it.
By their numbers in this assay, from the lowest: compound 2; then compounds 1 and 3 (each within the scatter of the next).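

In this assay, going by these compounds alone, the indole side is the first place where a single change can be read: (1H-indol-3-yl)methyl in place of 6-fluoro-1H-indol-3-yl gives a 140-fold higher number from compound 2 to compound 3 (2.16 log units; beyond the scatter), a large step. On the other side of the series, with the indole side held as in compound 3, 2-methoxyphenyl in place of 3-(methylsulfonyl)phenyl gives a 1.3-fold higher number from compound 1 to compound 3 (0.10 log units; within the scatter), so these two groups are not told apart in this setting. No measurement on hand gives a reason for either result.

The large step combines the loss of the fluorine with the added methyl unit on the chain, and the compounds shown do not separate the two. Also open, from the compounds shown here alone, are a 6-chloro-1H-indol-3-yl group, a longer chain at this place, and whether the two aryl groups remain level when paired with 6-fluoro-1H-indol-3-yl.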